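Methyl in Place of Fluoro: From Compound 2 to Compound 3

A few compounds are considered here, and "the series" means these few. Any claim that something is new, unique, unknown or untested is made for them only; others in the source may bear on it.

Compound 2 `Cc1cc(NC(=O)Cn2nnc(-c3cccc(F)c3)n2)n(C2CCCCC2)n1` gives 81 nM in an assay on HEK293 cells for activation of Kir3.1/Kir3.2 (Homo sapiens), read by thallium flux (on this read-out higher numbers stand for an effect only at larger amounts of compound and lower numbers for an effect already at smaller amounts), the lower of the two numbers shown, though its gap to compound 1 `Cc1cc(NC(=O)Cn2nnc(-c3ccccc3)n2)n(C2CCC(F)(F)CC2)n1`, which gives 84 nM, lies within the scatter. Compound 3 `Cc1cccc(-c2nnn(CC(=O)Nc3cc(C)nn3C3CCCCC3)n2)c1` differs from compound 2 by methyl in place of fluoro on an aromatic carbon. Among the compounds with values here, no measured pair shows what this change does, so no step beyond the scatter is expected in either direction in this assay. Compound 3 is expected to give about 90 nM, with a range of 40 nM to 200 nM. The expected step from compound 2 to compound 3 is a 1.1-fold higher number from compound 2 to compound 3 (0.05 log units; within the scatter).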

Compound 3, half-maximal effective concentration: 129 nM
Compound 3: middle estimate off by 1.4-fold (0.16 log units), on the low side; measured number inside the range.
By their numbers in this assay, from the lowest: compounds 2, 1 and 3 (each within the scatter of the next).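

In this assay, the change from 3-fluorophenyl to 3-methylphenyl now has a measured pair, with a 1.6-fold higher number from compound 2 to compound 3 (0.20 log units; within the scatter). At this position on the six-membered aromatic ring, methyl and fluoro therefore cannot be told apart in this read-out. No measurement on hand bears on the reason for this result. Going by these compounds, what an amine, a methoxy group or a carboxylic acid would do at this position remains open. So does whether the same change would read alike on the compound 1 scaffold.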